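From Ester Chain to Carboxyethyl Chain in Compound 4

The source may report more compounds than this note shows. Statements on the series, on what has been measured and on what is new or still open speak of the compounds shown alone.

Of the compounds shown here, three have been measured in a functional assay on DU-145 cells (Homo sapiens) for cytotoxicity, read by trypan blue exclusion, with a stated time of 96 h (on this read-out lower numbers stand for stronger inhibition and higher numbers for weaker inhibition), and their values lie far apart. Compound 1 (`COc1cc(OC)c(/C=C/S(=O)(=O)Nc2ccc(OC)c(OC(=O)C(C)(C)C3=C(C)C(=O)C=C(C)C3=O)c2)c(OC)c1`) gives 9 nM, while compound 2 (`COc1ccc(NS(=O)(=O)/C=C/c2cc(OC)c(OC)c(OC)c2)cc1[N+](=O)[O-]`) gives 75000 nM. Compound 3 (`COC(=O)CNc1cc(NS(=O)(=O)/C=C/c2c(OC)cc(OC)cc2OC)ccc1OC`) gives 350 nM, the second highest of the three numbers and beyond the scatter from both of the others.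

The next compound, compound 4 (`COc1cc(OC)c(/C=C/S(=O)(=O)Nc2ccc(OC)c(NC(C)C(=O)O)c2)c(OC)c1`), has not yet been measured. It carries 1-carboxyethyl in place of (methoxycarbonyl)methyl on a nitrogen on an aromatic ring, so the two compounds have the same atoms, joined differently. Among the compounds with values here, no pair of measured compounds differs in one place, so the data give no direct precedent for the size of this step.

The best anchor is compound 3 at 350 nM, since it alone among the measured compounds has a substituted chain on this nitrogen. A step within the scatter is therefore expected, leaning slightly towards weaker inhibition, though a larger move in either direction cannot be ruled out. The expected change is a 1.4-fold higher number from compound 3 to compound 4 (0.15 log units; within the scatter). For compound 4, the estimated value is 500 nM, with an expected range of 60 nM to 4000 nM.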

Compound 4, half-maximal inhibitory concentration: 40 nM
Beside the measured number, compound 4's estimate is 13-fold (1.10 log units) above it; the whole stated range lies above it.
By their numbers in this assay, from the lowest: compound 1; then compound 4; then compound 3; then compound 2.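

Within the data shown here, on a nitrogen on an aromatic ring, replacing (methoxycarbonyl)methyl with 1-carboxyethyl is the first change here that can be read on its own: in this assay it gives an 8.8-fold lower number from compound 3 to compound 4 (0.94 log units; beyond the scatter) and this lies beyond the usual scatter. The position therefore responds to how the chain is built, even though both chains have 5 heavy atoms of the same kinds, and the entering chain has 1 hydrogen-bond donor where the leaving chain has 0. No measurement given here accounts for this difference.

The step combines two differences, since the ester becomes a carboxylic acid and the attachment point of the chain gains a methyl branch, so the compounds shown cannot assign the gain to either one. Carboxymethyl on the same nitrogen, which keeps the carboxylic acid without the branch, and 1-(methoxycarbonyl)ethyl, which keeps the branch with the methyl ester, would separate the two, while a longer chain such as 2-carboxyethyl would test whether the spacing of the carboxylic acid from the nitrogen matters.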